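The source may hold more compounds than are shown below. What is called first, only, known or untested is meant among the compounds shown, and "the series" means these compounds.

- compound 1 `O=C(CCC1=CCCN(Cc2ccc(F)cc2)C1=O)NO`: 9960 nM
- compound 2 `O=C(CCC1=CCCN(Cc2ccc3ccccc3c2)C1=O)NO`: "not determined" (no result reported)
- compound 3 `O=C(CCC1=CCCN(CCCc2ccc(-c3ccccc3)cc2)C1=O)NO`: 3190 nM

In a functional assay on HCT-15 cells (Homo sapiens) for inhibition, read by sulforhodamine B assay (on this read-out lower numbers stand for stronger inhibition of growth and higher numbers for weaker inhibition of growth), compound 1 stands highest of the two available numbers, so it shows the weaker inhibition of growth. Compound 3 lies lower, beyond the scatter. Compound 4 `O=C(CCC1=CCCN(Cc2ccc(NC(=O)c3ccccc3)cc2)C1=O)NO` keeps the core of compound 1 but has benzamido in place of fluoro on an aromatic carbon. Among the compounds with values here, no measured pair shows this change alone. Within the data shown here, the only guide carries a larger group than compound 1 and differs in more than one place: compound 3 gives 3190 nM. A modest step towards a lower number in this assay is therefore expected, and it may stay close to the scatter. The expected change is a 2.5-fold lower number from compound 1 to compound 4 (0.40 log units; beyond the scatter). The estimated value for compound 4 is 4000 nM, with an expected range from 1300 nM to 12000 nM.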

Compound 4, concentration for 50% growth inhibition: > 10000 nM
Compound 4 was reported as a limit; the forecaster's own chance of this, stated with the estimate: 5%; at least 2.5-fold (0.39 log units) between middle value and limit.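

In this assay, putting benzamido in place of fluoro on this aromatic carbon gives a number no lower from compound 1 to compound 4 (the limit leaves the size open). For compound 4, the reported > 10000 nM is a limit of the assay and not a number. The earlier compounds shown here had no pair with this change alone; this pair shows that the larger benzamido group brought no lower number at this position, though the size of the step cannot be read.

As far as these compounds go, it remains open whether an amine or a methoxy group at this place would give a lower number than fluoro.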